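The compounds below may be only part of what the source reports. "The series", "measured", "known", "first", "only" and "open" are said of these compounds alone.

Compound 1 `Oc1ccccc1Nc1nccc(-c2c[nH]c3ccccc23)n1` and compound 2 `CCCCOc1nc(C)c(-c2ccnc(Nc3ccc(OC)cc3OC)n2)s1` were both tested in a functional assay on MV4-11 cells (Homo sapiens) for inhibition, read by resazurin assay, with a stated time of 72 h; on this read-out lower numbers stand for stronger inhibition of growth and higher numbers for weaker inhibition of growth. In this assay compound 1 gives 570 nM. Compound 2 stands at the higher of the two numbers: in this assay compound 2 gives 7860 nM, and the gap to compound 1 is beyond the scatter of repeated measurements. Compound 3 `CCCSc1nc(C)c(-c2ccnc(Nc3ccc(OC)cc3OC)n2)s1` has not yet been measured. It differs from compound 2 in one place (propylsulfanyl in place of butoxy on an aromatic carbon). The butoxy that leaves and the propylsulfanyl that enters are both chains with no ring, no hydrogen-bond donor and one hydrogen-bond acceptor. Among the compounds with values here, no pair of measured compounds shows what this kind of exchange does in this assay, so the expectation rests on compound 2 alone. Compound 3 is expected to stay close to compound 2, with a step of a 1.1-fold lower number from compound 2 to compound 3 (0.05 log units; within the scatter) that does not go beyond the scatter. The estimate for compound 3 in this assay is 7000 nM, between 3000 nM and 16000 nM.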

Compound 3, concentration for 50% growth inhibition: 2240 nM
Estimate against measurement, compound 3: 3.1-fold (0.49 log units) above, outside the stated range (below it).
By their numbers in this assay, from the lowest: compound 1; then compound 3; then compound 2.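

On this aromatic carbon, next to the ring nitrogen and next to the ring sulfur, the read-out responds to the chain it carries: in this assay the exchange of butoxy for propylsulfanyl gives a 3.5-fold lower number from compound 2 to compound 3 (0.55 log units; beyond the scatter), a modest step. Both chains have no ring and no net charge, but the length of the chain and the atom joining it to the ring change together, and this single pair cannot tell the two changes apart. No measured property of either chain bears on this step, so nothing can be said about its cause.

The compounds shown leave open whether a propoxy or a butylsulfanyl chain on this carbon would follow the same direction. They also leave open how an amine or a carboxylic acid would fare at this position.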